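Swapping the Terminal Ring on a Urea Tail

A few compounds are considered here, and "the series" means these few. Any claim that something is new, unique, unknown or untested is made for them only; others in the source may bear on it.

Compound 1 `COc1cc(-c2nn(-c3cccc(NC(=O)c4ccc(Cl)c(C(F)(F)F)c4)c3)cc2-c2ccncc2)ccc1Cl`: 19700 nM
Compound 2 `COc1cc(-c2nn(-c3cccc(NC(=O)Nc4cccc(C(F)(F)F)c4)c3)cc2-c2ccncc2)ccc1Cl`: 1960 nM
Compound 3 `O=C(Nc1cccc(-n2cc(-c3ccncc3)c(-c3ccc(Cl)c(O)c3)n2)c1)Nc1cccc(C(F)(F)F)c1`: 10800 nM

In a functional assay on SK-MEL-2 cells (Homo sapiens) for inhibition, read by sulforhodamine B assay, with a stated time of 48 h (a higher number here means a weaker inhibitor of growth, a lower number a stronger inhibitor of growth), compound 2 gives the lowest of the three numbers: a 10-fold lower number from compound 1 to compound 2 (1.00 log units; beyond the scatter), and a 5.5-fold higher number from compound 2 to compound 3 (0.74 log units; beyond the scatter). Compound 4 `COc1cc(-c2nn(-c3cccc(NC(=O)Nc4ccc(Cl)c(Cl)c4)c3)cc2-c2ccncc2)ccc1Cl` keeps everything of compound 2 except the outermost ring of the urea tail: 3,4-dichlorophenyl in place of 3-(trifluoromethyl)phenyl on an amide-type nitrogen. Within the data shown here, the step from compound 1 to compound 2 touched the same end of the molecule, but it also changed the linker from amide to urea, so no measured step isolates a swap of this terminal ring; the step from compound 2 to compound 3 concerns a different part and does not bear on it. A modest change at most is therefore expected, estimated as a 1.3-fold higher number from compound 2 to compound 4 (0.11 log units; within the scatter). Compound 4 is expected to give about 2500 nM, with a likely range from 800 nM to 8000 nM.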

Compound 4, concentration for total growth inhibition: 2350 nM
For compound 4 the middle estimate is 1.1-fold (0.03 log units) above the measured one, and the stated range covers the measured number.
By their numbers in this assay, from the lowest: compounds 2 and 4 (each within the scatter of the next); then compounds 3 and 1 (each within the scatter of the next).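

In this assay the 3-(trifluoromethyl)phenyl on the urea tail can give way to 3,4-dichlorophenyl with a 1.2-fold higher number from compound 2 to compound 4 (0.08 log units; within the scatter) and the two numbers cannot be told apart, so this terminal ring can change without a readable shift. With an 8.4-fold lower number from compound 1 to compound 4 (0.92 log units; beyond the scatter) as well, both ureas with their different terminal rings stand clear of the amide compound 1. Nothing measured here explains these results. Still open, from the compounds shown here alone, is how a terminal ring carrying an amine or a carboxylic acid would compare. Also open, going by these compounds, is whether replacing the methoxy methyl with hydrogen, the change that weakened compound 2, would do the same with the 3,4-dichlorophenyl tail of compound 4.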